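A Second Fluoromethyl Group on Compound 3

This account rests on a few compounds, and the source may have more. Where it says the series, first, only, none or still open, it means among the compounds named here.

Of the compounds shown here, three have so far been measured in a functional assay (aorta) with Rattus norvegicus as the target; on this read-out lower numbers stand for an effect already at smaller amounts and higher numbers for an effect only at larger amounts of compound. Compound 1 `C/N=C(/S)C1=CC(C)(C)Oc2ccc([N+](=O)[O-])cc21` gives 1.35 nM in this assay. Compound 2 `C/N=C(/S)C1=CC(C)(CF)Oc2ccc([N+](=O)[O-])cc21` differs from compound 1 in one place: fluoro in place of hydrogen on a saturated chain carbon bound to a saturated ring carbon In this assay compound 2 gives 1.62 nM, so that a 1.2-fold higher number from compound 1 to compound 2 (0.08 log units; within the scatter). Compound 3 `CNC(=O)C1=CC(C)(CF)Oc2ccc([N+](=O)[O-])cc21` differs from compound 2 in a different place, and in this assay compound 3 gives 8.91 nM; here a 5.5-fold higher number from compound 2 to compound 3 (0.74 log units; beyond the scatter). The difference between the core of compound 1 and the core of compound 3 is not broken down here.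

Compound 4 `CNC(=O)C1=CC(CF)(CF)Oc2ccc([N+](=O)[O-])cc21` has not yet been measured. Relative to compound 3 it carries one change: fluoro in place of hydrogen on a saturated chain carbon bound to a saturated ring carbon This is the same change that separates compound 1 from compound 2, made at the same place, and it occurs twice among the compounds shown. The earlier step, where a 1.2-fold higher number from compound 1 to compound 2 (0.08 log units; within the scatter), stayed within the scatter, and the corresponding step on the core of compound 3 is therefore expected to be similarly small: a 1.2-fold higher number from compound 3 to compound 4 (0.07 log units; within the scatter). On this basis compound 4 is estimated to give 10.5 nM in this assay, with a likely range from 5 nM to 22 nM.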

Compound 4, half-maximal effective concentration: 5.13 nM
Estimate against measurement, compound 4: 2.0-fold (0.31 log units) above; the measured number falls inside the stated range.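

In this assay, fluoro in place of hydrogen on a saturated chain carbon bound to a saturated ring carbon gives a 1.7-fold lower number from compound 3 to compound 4 (0.24 log units; within the scatter), so this methyl to fluoromethyl change again stays within the scatter. Set beside the earlier step, the change shows no difference that can be told apart between the two cores: the same change on two cores in this assay, a 1.2-fold higher number (0.08 log units; within the scatter) from compound 1 to compound 2 and a 1.7-fold lower number (0.24 log units; within the scatter) from compound 3 to compound 4, 2.1-fold (0.32 log units) apart, within the scatter of two such steps This shows that the change stayed small on both cores, but it rests on only two pairs in a single assay; it does not show that the two steps are the same, or that the change would stay small on any other core in this series.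

The compounds shown leave open whether difluoromethyl, trifluoromethyl or an ethyl chain on that saturated ring carbon would also stay within the scatter. They also leave open whether a second methyl to fluoromethyl change on the core of compound 2 would behave as it does on the core of compound 3.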